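The source may hold more compounds than are shown below. What is called first, only, known or untested is meant among the compounds shown, and "the series" means these compounds.

Working notes on the series. In an assay on HEK293 cells for negative allosteric modulation of metabotropic glutamate receptor 5 (Homo sapiens), read by FLIPR, with a stated time of 1 h (on this read-out lower numbers stand for stronger inhibition and higher numbers for weaker inhibition), compound 1 `CN1CCc2nc(C#Cc3ccccc3)sc2C1` gives > 10000 nM, which is a limit of the assay. Compound 2 `CCCCN1CCc2nc(C#Cc3ccccc3)sc2C1` gives > 10000 nM, likewise a limit. Among the compounds with values here, compound 3 `O=C(C1CC1)N1CCc2nc(C#Cc3ccccc3)sc2C1` gives 290 nM, the only number among the three values shown, the other two sitting at the limit of > 10000 nM in this assay, at which 2 of the 3 values shown sit. The step that the two limits leave unreadable from compound 1 to compound 2 is not readable. By contrast the steps of an at least 34-fold lower number from compound 1 to compound 3 (1.53 log units; beyond the scatter) and an at least 34-fold lower number from compound 2 to compound 3 (1.53 log units; beyond the scatter) are large. Compound 4 `O=C(C1CCC1)N1CCc2nc(C#Cc3ccccc3)sc2C1` differs from compound 3 by cyclobutyl in place of cyclopropyl on a carbonyl carbon. Within the data shown here, no measured step alters the ring on the carbonyl carbon; both large steps concern the carbonyl group itself, which compound 4 keeps. In this assay the step expected for compound 4 is a 1.0-fold higher number from compound 3 to compound 4 (0.01 log units; within the scatter), within the scatter. Compound 4 is estimated at 300 nM, with a range of 100 nM to 900 nM.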

Compound 4, half-maximal inhibitory concentration: 370 nM
Compound 4: middle estimate off by 1.2-fold (0.09 log units), on the low side; the measured number falls inside the stated range.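

In this assay, within the data shown here, cyclobutyl in place of cyclopropyl on a carbonyl carbon gives a 1.3-fold higher number from compound 3 to compound 4 (0.11 log units; within the scatter) and so leaves compound 3 and compound 4 level, the first read on a change at this ring. The large steps seen for the carbonyl group persist with the larger ring: an at least 27-fold lower number from compound 2 to compound 4 (1.43 log units; beyond the scatter) and an at least 27-fold lower number from compound 1 to compound 4 (1.43 log units; beyond the scatter) are both read. Both steps start from a limit of the assay, held by compound 1 and compound 2: the limit of > 10000 nM in this assay, at which 2 of the 4 values shown sit.

As far as these compounds go, whether a cyclohexyl, a phenyl or an open chain such as isopropyl on the carbonyl carbon holds this level stays open. From the compounds shown here alone, a sulfonyl group in place of the carbonyl also stays open.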